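A few compounds are considered here, and "the series" means these few. Any claim that something is new, unique, unknown or untested is made for them only; others in the source may bear on it.

Measured so far in an assay on HEK293 cells for positive allosteric modulation of metabotropic glutamate receptor 5 (Homo sapiens), read by FLIPR; on this read-out higher numbers stand for an effect only at larger amounts of compound and lower numbers for an effect already at smaller amounts:
compound 1 `O=C([C@H]1CC2CCC1C2)N1CC(c2nc(-c3ccccc3)no2)C1` – 120 nM
compound 2 `O=C(c1ccc(F)c(F)c1)N1CC(c2nc(-c3cccc(F)c3)no2)C1` – 3200 nM
compound 3 `O=C(c1ccc(F)cc1)N1CC(c2nc(-c3cccc(Cl)c3)no2)C1` – > 10000 nM, a limit of this assay and not a number

Compound 3 stands only at the limit, as noted in the limit of > 10000 nM in this assay, at which 1 of the 3 values shown sits; no figure for it is available in this assay. Compound 4 `O=C(C1CCC2(CCC2)CC1)N1CC(c2nc(-c3cccc(Cl)c3)no2)C1` is the next compound to be measured. From compound 3 to compound 4 the change is a group of 9 heavy atoms (9 carbon; one four-membered non-aromatic ring of carbon only, one six-membered non-aromatic ring of carbon only) in place of a group of 7 heavy atoms (6 carbon, 1 fluorine; one six-membered aromatic ring of carbon only), on a carbonyl carbon. The amide side thus shifts from an aromatic to a saturated bicyclic group. Among the compounds with values here, no single-change step between measured compounds is available for this series; the values show that compound 1, carrying a saturated bicyclic amide, gives 120 nM, while compound 2 with an aromatic amide gives 3200 nM. A step toward smaller values, clearly beyond the scatter, is expected: an at least 16-fold lower number from compound 3 to compound 4 (1.22 log units; beyond the scatter). For compound 4 the estimate in this assay is 600 nM, with a range from 150 nM to 3000 nM.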

Compound 4, half-maximal effective concentration: 1100 nM
Beside the measured number, compound 4's estimate is 1.8-fold (0.26 log units) below it; low and high end bracket the measured number.
By their numbers in this assay, from the lowest: compound 1; then compound 4; then compound 2. At a limit, above all of these: compound 3.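

In this assay, the series now has its first change in a single place: on the carbonyl carbon, 4-fluorophenyl gives way to a saturated carbon group with one four-membered and one six-membered non-aromatic ring, and the result is an at least 9.0-fold lower number from compound 3 to compound 4 (0.95 log units; beyond the scatter). This step is a lower bound, as the value for compound 3 is a limit and not a number: the limit of > 10000 nM in this assay, at which 1 of the 4 values shown sits.

Still open, as far as these compounds go, is how a straight hexyl chain or a piperidine on the same carbonyl carbon would compare with the saturated group of compound 4.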